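Changing the Aromatic Ring on the Carbonyl

A few compounds are considered here, and "the series" means these few. Any claim that something is new, unique, unknown or untested is made for them only; others in the source may bear on it.

Measured in a functional assay on MCF7 cells (Homo sapiens) for antiproliferative activity, read by MTT assay, with a stated time of 72 h; on this read-out lower numbers stand for stronger inhibition and higher numbers for weaker inhibition:
- Compound 1 `CC1=CC[C@H]2[C@H](CC[C@]2(C)O)C(C)(C)[C@@H]1CC[C@H]1[C@]2(C)CC[C@H](OCc3ccccc3)C(C)(C)O[C@H]2CC[C@@]1(C)O`: > 50000 nM
- Compound 2 `CC1=CC[C@H]2[C@H](CC[C@]2(C)O)C(C)(C)[C@@H]1CC[C@H]1[C@]2(C)CC[C@H](OC(=O)c3ccc(Cl)c(Cl)c3)C(C)(C)O[C@H]2CC[C@@]1(C)O`: 11900 nM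

Compound 1 reads > 50000 nM, which is a limit and not a number. Within the data shown here, that leaves compound 2, at 11900 nM, as the only actual number so far in this assay. Among the measured compounds shown here, the one measured step is an at least 4.2-fold lower number from compound 1 to compound 2 (0.62 log units; beyond the scatter), with (3,4-dichlorophenyl)carbonyl in place of benzyl on an oxygen on a saturated carbon.

Compound 3 `CC1=CC[C@H]2[C@H](CC[C@]2(C)O)C(C)(C)[C@@H]1CC[C@H]1[C@]2(C)CC[C@H](OC(=O)c3ccccc3[N+](=O)[O-])C(C)(C)O[C@H]2CC[C@@]1(C)O` keeps the carbonyl and changes the ring attached to it: 2-nitrophenyl in place of 3,4-dichlorophenyl on a carbonyl carbon. In words, this is 2-nitrophenyl in place of 3,4-dichlorophenyl on a carbonyl carbon. For the measured compounds named here, no measured step makes this exact kind of swap. The step of an at least 4.2-fold lower number from compound 1 to compound 2 (0.62 log units; beyond the scatter) bears on it only loosely, since that change replaced benzyl with a carbonyl-bearing group, whereas here the carbonyl stays. A change within the usual scatter is therefore expected, with a slight lean towards weaker inhibition. The expected step is a 1.3-fold higher number from compound 2 to compound 3 (0.13 log units; within the scatter). Compound 3 is estimated at 16000 nM, with an expected range of 6000 nM to 45000 nM.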

Compound 3, half-maximal inhibitory concentration: 5200 nM
Compound 3: middle estimate off by 3.1-fold (0.49 log units), on the high side; measured number below the stated range.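

With the carbonyl kept in place, the ring attached to it still counts in this assay: 2-nitrophenyl in place of 3,4-dichlorophenyl gives a 2.3-fold lower number from compound 2 to compound 3 (0.36 log units; beyond the scatter). This position therefore responds to more than the presence of the carbonyl, and the earlier pair could not show that, since benzyl and the carbonyl-bearing group differ in the link as well as the ring. The change from benzyl to (2-nitrophenyl)carbonyl gives an at least 9.6-fold lower number from compound 1 to compound 3 (0.98 log units; beyond the scatter), and the size of that step is only a lower bound, as the value of compound 1 is a limit of the assay and not a number: the limit of > 50000 nM in this assay, at which 1 of the 3 values shown sits.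

The two rings differ in both their groups and where those groups sit, so these compounds cannot separate the effect of adding the nitro group from that of losing the two chlorines, or either of these from the placing on the ring. As far as these compounds go, how an unsubstituted phenyl ring, or a ring carrying an amine or a carboxylic acid, would read on the same carbonyl remains open.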